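The source may hold more compounds than are shown below. What is called first, only, known or untested is meant among the compounds shown, and "the series" means these compounds.

The measured compounds:

Compound 1, `CC(=O)/C(C)=C/c1ccc([N+](=O)[O-])cc1`: 70500 nM
Compound 2, `CC(=O)/C(C)=C/c1ccc(N(C)C)cc1`: 160000 nM
Compound 3, `COc1ccc(/C=C(\C)C(=O)/C=C/c2ccc([N+](=O)[O-])cc2)cc1`: 30000 nM

All three were tested in an ADME assay on J774.A1 cells (Mus musculus) for cytotoxicity, read by MTT assay, with a stated time of 48 h; a higher number here means that more compound is tolerated, a lower number that less compound is tolerated. Compound 1 and compound 2 share a core and differ in one place: dimethylamino in place of nitro on an aromatic carbon. That exchange gave a 2.3-fold higher number from compound 1 to compound 2 (0.36 log units; beyond the scatter), so more of compound 2 was tolerated than of compound 1. Compound 3 has a different core; the difference between the two cores is not broken down here. Compound 3 gives the lowest of the three numbers in this assay, and the values of compound 3 and compound 2 show the widest gap among the three.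

Compound 4, `COc1ccc(/C=C(\C)C(=O)/C=C/c2ccc(N(C)C)cc2)cc1`, is not yet measured. It stands to compound 3 as compound 2 stands to compound 1: dimethylamino in place of nitro on an aromatic carbon. The surroundings are not identical, since in compound 3 the group sits para to a large group rather than para to a group of 6 heavy atoms, so this is the same kind of change, not the same change. If it behaves as it did from compound 1 to compound 2, a step of a 2.2-fold higher number from compound 3 to compound 4 (0.34 log units; beyond the scatter) is expected for compound 4 in this assay, because of a 2.3-fold higher number from compound 1 to compound 2 (0.36 log units; beyond the scatter). The estimate for compound 4 is therefore 65000 nM, expected to fall between 30000 nM and 140000 nM.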

Compound 4, half-maximal cytotoxic concentration: 36200 nM
For compound 4 the middle estimate is 1.8-fold (0.25 log units) above the measured one; measured number inside the range.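

Exchanging nitro for dimethylamino on the larger core gave a 1.2-fold higher number from compound 3 to compound 4 (0.08 log units; within the scatter) in this assay, so compound 3 and compound 4 cannot be told apart here. Set beside the same exchange on the smaller core, the result does not differ by more than two such steps can scatter: the same change on two cores in this assay, a 2.3-fold higher number (0.36 log units; beyond the scatter) from compound 1 to compound 2 and a 1.2-fold higher number (0.08 log units; within the scatter) from compound 3 to compound 4, 1.9-fold (0.27 log units) apart, within the scatter of two such steps

This means that the data give no reason to say the exchange behaves differently on the two cores, but they do not prove that it carries over unchanged, since the step is clear on one core and lost in the scatter on the other, and two pairs are a thin basis for any rule. The compounds shown leave open whether groups other than these two, such as a chlorine atom, a carboxylic acid or a primary amine, would separate the two cores more clearly in that place on the ring. They also leave open whether the exchange would follow the same course on any further core.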